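Benzoyl on the Amino Nitrogen: Expected Maximal Response

The compounds below may be only part of what the source reports. "The series", "measured", "known", "first", "only" and "open" are said of these compounds alone.

Compound 1 `Nc1nc(-c2ccc(Cl)cc2)c(CC(=O)O)s1` carries an amino group on its shared core. In an in vitro functional assay on HEK285-7 cells for antagonist activity at prostaglandin D2 receptor 2 (Homo sapiens), read by BRET and beta-arrestin recruitment (a lower number here means a smaller maximal response, a higher number a larger maximal response), compound 1 gives 50%. Compound 2 `O=C(O)Cc1sc(Cc2ccccc2)nc1-c1ccc(Cl)cc1` gives 50% in this assay, and compound 3 `O=C(O)Cc1sc(CSc2ccccc2)nc1-c1ccc(Cl)cc1` gives 50%, so compound 1 sits level with both. The step of no change at the digits printed from compound 1 to compound 2 (within the scatter) puts benzyl in place of amino, the step of no change at the digits printed from compound 1 to compound 3 (within the scatter) puts (phenylsulfanyl)methyl in place of amino, and the step of no change at the digits printed from compound 2 to compound 3 (within the scatter) swaps phenyl for phenylsulfanyl. Compound 4 `O=C(O)Cc1sc(NC(=O)c2ccccc2)nc1-c1ccc(Cl)cc1` differs from compound 1 by benzoyl in place of hydrogen on a nitrogen on an aromatic ring. Because no change at the digits printed from compound 1 to compound 2 (within the scatter) and no change at the digits printed from compound 1 to compound 3 (within the scatter) stayed flat, the step of no change at the digits printed from compound 1 to compound 4 (within the scatter) is expected to lie within the scatter. Compound 4 is therefore estimated at 50%, with a range from 35% to 65%.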

Compound 4, largest response reached (reported as efficacy), in percent of the reference or control that the assay uses: 50%
Estimate against measurement, compound 4: no gap at the digits printed, and the stated range covers the measured number.
By their numbers in this assay, from the lowest: compounds 1, 2, 3 and 4 (each within the scatter of the next).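

A benzoyl on the nitrogen gives no change at the digits printed from compound 1 to compound 4 (within the scatter) in this assay and so shows that the amino nitrogen can stay in place and carry an amide carbonyl and an aromatic ring with the maximal response still level. Compounds 2 and 3 had replaced the amino group outright, so this position now stays flat with the nitrogen either kept or gone. Nothing measured here explains that flatness.

Going by these compounds, whether a smaller acetyl on the same nitrogen would also leave the response level remains open. So does whether any group at this position, such as a longer alkyl chain or a carboxylic acid, would move it at all.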